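The source may report more compounds than this note shows. Statements on the series, on what has been measured and on what is new or still open speak of the compounds shown alone.

In a functional assay on COLO 205 cells (Homo sapiens) for antiproliferative activity (a higher number here means a weaker inhibitor of growth, a lower number a stronger inhibitor of growth), compound 1 `COCCCCCCCCCCC/C=C1\CC(CO)(COC(=O)C(C)(C)C)OC1=O` gives 0.541 ug/mL and compound 2 `CCCCCOCCCCCCC/C=C1\CC(CO)(COC(=O)C(C)(C)C)OC1=O` gives 0.491 ug/mL in this pair. Among the measured compounds shown here, the one measured step of a 1.1-fold lower number from compound 1 to compound 2 (0.04 log units; within the scatter) lies within the scatter, so compound 2 holds no rank apart from compound 1. Compound 3 `CC(C)(C)C(=O)OCC1(CO)C/C(=C\CCCCCCCCCCCO)C(=O)O1` follows from compound 2 by a single change 4-hydroxybutyl in place of pentyloxy on a saturated chain carbon, seven bonds along the chain from a double-bonded chain carbon in the chain, that is 4-hydroxybutyl in place of pentyloxy on a saturated chain carbon, seven bonds along the chain from a double-bonded chain carbon. The step of a 1.1-fold lower number from compound 1 to compound 2 (0.04 log units; within the scatter) only exchanged one ether chain for another, so it bears on this change weakly. Neither measured compound ends in a free hydroxyl, and the data therefore leave this kind of chain end untested. A moderate move toward a higher number is expected in this assay on judgement alone, with a wide margin on both sides. The expected size is a 1.8-fold higher number from compound 2 to compound 3 (0.26 log units; within the scatter) as a rough estimate. For compound 3 the estimate is 0.9 ug/mL with an expected range from 0.35 ug/mL to 2.5 ug/mL overall.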

Compound 3, concentration for 50% growth inhibition: 2.49 ug/mL
The estimate for compound 3 lay 2.8-fold (0.44 log units) below the measured number; measured number inside the range.
By their numbers in this assay, from the lowest: compounds 2 and 1 (each within the scatter of the next); then compound 3.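

In this assay the chain end proves not to be silent: the two ether-ended chains sat within the scatter of each other, but 4-hydroxybutyl in place of pentyloxy gives a 5.1-fold higher number from compound 2 to compound 3 (0.71 log units; beyond the scatter) and so moves beyond it. The tighter comparison is a 4.6-fold higher number from compound 1 to compound 3 (0.66 log units; beyond the scatter) with hydrogen in place of methyl on an oxygen on a saturated carbon as the only difference, so uncapping the terminal oxygen is enough to weaken growth inhibition in these three compounds, while the two ether ends tolerate a swap of one for the other. No measurement on hand accounts for this shift.

Open, as far as these compounds go, is whether the shift belongs to the free hydroxyl specifically or would also appear with another chain end, such as a terminal amine, a carboxylic acid or an acetate ester. Also open, from the compounds shown here alone, is whether a terminal hydroxyl on a shorter or a longer chain behaves as it does here, and whether a longer alkyl group on the terminal oxygen keeps the level of the two ethers.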